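Swapping the aryl amine substituent of a thiourea sulfonamide

The source may hold more compounds than are shown below. What is called first, only, known or untested is meant among the compounds shown, and "the series" means these compounds.

Three compounds have numbers in a functional assay on NCI-H1975 cells (Homo sapiens) for antiproliferative activity, read by MTT assay, with a stated time of 72 h; on this read-out higher numbers stand for weaker inhibition and lower numbers for stronger inhibition. Going by the values given here, compound 1 `COc1cc2ncnc(Nc3ccc(Cl)cc3)c2cc1OCCCCC(=O)Nc1ccc(S(N)(=O)=O)cc1` gives 31800 nM, and compound 2 `COc1cc2ncnc(Nc3cccc(Cl)c3F)c2cc1OCCCCC(=O)Nc1ccc(S(N)(=O)=O)cc1` gives 6930 nM; the step of a 4.6-fold lower number from compound 1 to compound 2 (0.66 log units; beyond the scatter) is the only single-point change measured here, and it lies in the group carried on a nitrogen on an aromatic ring. Compound 3 `NS(=O)(=O)c1ccc(NC(=S)Nc2ccc3ncnc(Nc4ccc(Cl)c(C(F)(F)F)c4)c3c2)cc1`, which carries a thiourea linker instead of the chain of the first two, gives 11800 nM in this assay; that is the second highest of the three numbers, within the scatter of compound 2 and beyond the scatter from compound 1.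

Compound 4 `NS(=O)(=O)c1ccc(NC(=S)Nc2ccc3ncnc(Nc4cccc(F)c4)c3c2)cc1` differs from compound 3 by 3-fluorophenyl in place of 4-chloro-3-(trifluoromethyl)phenyl on a nitrogen on an aromatic ring. Among the compounds with values here, the only measured step that touches the same place is the one from compound 1 to compound 2, which moved the number modestly when the group on that nitrogen changed, though on a different linker. On that basis a modest shift is expected for compound 4, with the direction uncertain, and the estimated step of a 1.3-fold higher number from compound 3 to compound 4 (0.10 log units; within the scatter) is small. Compound 4 is therefore expected to give about 15000 nM in this assay, most likely between 4000 nM and 50000 nM.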

Compound 4, half-maximal inhibitory concentration: 9660 nM
Beside the measured number, compound 4's estimate is 1.6-fold (0.19 log units) above it, and the stated range covers the measured number.
By their numbers in this assay, from the lowest: compounds 2, 4 and 3 (each within the scatter of the next); then compound 1.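

On the thiourea linker, the group on a nitrogen on an aromatic ring could be exchanged in this assay with no readable effect, with a 1.2-fold lower number from compound 3 to compound 4 (0.09 log units; within the scatter) as the result. Going by these compounds alone, the 3-fluorophenyl, with fewer heavy atoms, stands in for the 4-chloro-3-(trifluoromethyl)phenyl, so on this linker neither the chlorine nor the trifluoromethyl group is needed to keep the number where it was, while the one earlier step at this place, a 4.6-fold lower number from compound 1 to compound 2 (0.66 log units; beyond the scatter), was on the other linker and involved a different pair of groups. Nothing measured here explains why the two steps differ in size.

Every group shown on this nitrogen is a phenyl ring bearing halogen, so it remains open how a plain phenyl, or a phenyl carrying a methoxy group, an amine or a carboxylic acid, would read on the thiourea linker. Going by these compounds, it is also open whether the 3-fluorophenyl would read the same way on the chain of compound 1 and compound 2, where the choice of group did move the number.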